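Cutting back the long chain of compound 2

This account rests on a few compounds, and the source may have more. Where it says the series, first, only, none or still open, it means among the compounds named here.

Three compounds share one core and differ only in the group on a thiocarbonyl carbon. In a functional assay on DU-145 cells (Homo sapiens) for inhibition, read by MTT assay, with stated times of 18 h and 4 h (a lower number here means a stronger inhibitor, a higher number a weaker inhibitor), compound 1 `CCCCCCCCCCCCCCCCOP(=O)(O)OCCSC(=S)N1CCCCCC1` gives 17600 nM, compound 2 `CCCCCCCCCCCCCCCCOP(=O)(O)OCCSC(=S)N1CCN(C)CC1` gives 49300 nM and compound 3 `CCCCCCCCCCCCCCCCOP(=O)(O)OCCSC(=S)N1CCCC1` gives 28900 nM. Compound 2 sits at the weak end of this small set, as the data show a 1.7-fold lower number from compound 2 to compound 3 (0.23 log units; within the scatter) and a 2.8-fold higher number from compound 1 to compound 2 (0.45 log units; beyond the scatter).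

Compound 4 `CCCCCCOP(=O)(O)OCCSC(=S)N1CCN(C)CC1` has not been measured. It keeps the 4-methylpiperazin-1-yl group of compound 2 but carries hydrogen in place of decyl on a saturated chain carbon, six bonds along the chain from an oxygen on an unsaturated carbon. Within the data shown here, no measured step touches this chain, so the three compounds offer only an indirect guide. Their largest step, a 2.8-fold higher number from compound 1 to compound 2 (0.45 log units; beyond the scatter), came from swapping one group on the thiocarbonyl carbon. Losing so much of the chain is a far bigger change, so a clear move towards a higher number in this assay is expected. The expected size is a 2.4-fold higher number from compound 2 to compound 4 (0.39 log units; beyond the scatter). For compound 4 the estimate is 120000 nM, with an expected range of 45000 nM to 350000 nM.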

Compound 4, half-maximal inhibitory concentration: > 100000 nM
Compound 4 gave a limit, no number; the forecaster's own chance of this, stated with the estimate: 35%; the middle value is on the limit's open side.
By their numbers in this assay, from the lowest: compounds 1, 3 and 2 (each within the scatter of the next, the first and the last beyond it). At a limit, above all of these: compound 4.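

Replacing decyl with hydrogen, while keeping the 4-methylpiperazin-1-yl group, is the only change shown that touches the chain rather than the group on the thiocarbonyl carbon, and in this assay it gives an at least 2.0-fold higher number from compound 2 to compound 4 (0.30 log units; that floor lies within the scatter). Compound 4 gives > 100000 nM, which is a limit and not a number. The step can be read only as a floor, with its true size unknown, because it ends at a limit: the limit of > 100000 nM in this assay, at which 1 of the 4 values shown sits.

Going by these compounds, how the number moves when only part of the decyl is removed remains open, as does the effect of a longer chain or of an amine in place of decyl. Also open, on these data alone, is whether the azepan-1-yl and pyrrolidin-1-yl groups would give the same result on the cut-back chain.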